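A few compounds are considered here, and "the series" means these few. Any claim that something is new, unique, unknown or untested is made for them only; others in the source may bear on it.

Values so far in a physicochemical assay for solubility, at pH 7.4; a lower number here means a less soluble compound, a higher number a more soluble compound
- Compound 1 `CN1CCN(c2ccc(C(=O)/C=C/c3ccc(/C=C/C(=O)NO)cc3)cc2)CC1` gives 1000 nM
- Compound 2 `O=C(/C=C/c1ccc(/C=C/C(=O)c2ccccc2)cn1)NO` gives 27000 nM

Compound 2 stands highest of the two, and the gap to compound 1 lies beyond the scatter. Compound 3 `CN1CCN(c2ccccc2C(=O)/C=C/c2ccc(/C=C/C(=O)NO)nc2)CC1` departs from compound 2 by 4-methylpiperazin-1-yl in place of hydrogen on an aromatic carbon, with 4-methylpiperazin-1-yl in place of hydrogen on an aromatic carbon. Among the compounds with values here, no measured pair shows this change alone. Compound 1 also carries 4-methylpiperazin-1-yl and gives 1000 nM while compound 2 gives 27000 nM, although these two differ elsewhere too. A moderate fall beyond the scatter is therefore expected, the estimated step being a 2.7-fold lower number from compound 2 to compound 3 (0.43 log units; beyond the scatter) in this series. For compound 3 the estimated value is 10000 nM, with 2500 nM to 40000 nM as its expected range.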

Compound 3, solubility: 469000 nM
For compound 3 the middle estimate is 47-fold (1.67 log units) below the measured one, and the stated range ends below it.
By their numbers in this assay, from the lowest: compound 1; then compound 2; then compound 3.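

On an aromatic carbon of the six-membered aromatic ring of carbon only, ortho to a large group, 4-methylpiperazin-1-yl in place of hydrogen gives in this assay a 17-fold higher number from compound 2 to compound 3 (1.24 log units; beyond the scatter) as a large upward step. Within the data shown here, this is the first comparison that isolates a single change, and here the substitution raises the number. Nothing measured here accounts for the step.

On these data alone, whether the step needs the whole 4-methylpiperazin-1-yl group remains open, as does its size at other ring carbons. A morpholine or a dimethylamino group on this carbon would test the first point.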